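This account rests on a few compounds, and the source may have more. Where it says the series, first, only, none or still open, it means among the compounds named here.

Series notes on a functional assay on KB cells (Homo sapiens) for inhibition; a higher number here means a weaker inhibitor, a lower number a stronger inhibitor. Compound 1 `CNc1c(C#N)c2c(N)ncnc2n1COCCOC` and compound 3 `COCCOCn1cc(C#N)c2c(N)ncnc21` share a core; compound 2 `COc1ccc(Cn2c(N)c(C#N)c3c(N)ncnc32)cc1` carries a benzyl-type substituent on the same core.

For compound 1 the assay returns only a limit, > 100000 nM. For compound 3 likewise only a limit is returned, > 100000 nM. Among the measured compounds shown here, the one single-point step, a step that the two limits leave unreadable from compound 1 to compound 3, therefore cannot be sized. For the measured compounds named here, compound 2 gives 50000 nM, the only number in the set. The other two values, those of compound 1 and compound 3, sit at the limit (the limit of > 100000 nM in this assay, at which 2 of the 3 values shown sit).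

Compound 4 `N#Cc1c(N)n(Cc2ccccc2)c2ncnc(N)c12` is the next entry. Relative to compound 2 the change is hydrogen in place of methoxy on an aromatic carbon. Going by the values given here, no measured step concerns a methoxy-for-hydrogen change, so nothing bears on it, and the expected step of no change at the digits printed from compound 2 to compound 4 (within the scatter) is none beyond the scatter. Compound 4 is estimated at 50000 nM, between 15000 nM and 150000 nM.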

Compound 4, half-maximal inhibitory concentration: 34000 nM
Compound 4: middle estimate off by 1.5-fold (0.17 log units), on the high side; the measured number falls inside the stated range.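

In this assay, hydrogen in place of methoxy on an aromatic carbon para to a large group gives a 1.5-fold lower number from compound 2 to compound 4 (0.17 log units; within the scatter). Among the compounds shown here, this is the first step that can be sized, and it shows that the methoxy can be lost from this position with no change beyond the scatter. Nothing on record gives a cause for this step.

Going by these compounds, whether a chlorine atom, an amine or a carboxylic acid at this position would move the number beyond the scatter remains open.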